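Inverting one ring stereocentre in a hexyl-substituted sulfonamide

The source may hold more compounds than are shown below. What is called first, only, known or untested is meant among the compounds shown, and "the series" means these compounds.

Compound 1, `CCN1CCC[C@@H]1CNC(=O)c1cc(S(N)(=O)=O)cc2c1O[C@@H](C)C2`, in a functional assay on the whole organism with Mus musculus as the target (on this read-out higher numbers stand for an effect only at larger amounts of compound and lower numbers for an effect already at smaller amounts), compound 1 gives 71.7 mg/kg.
Compound 2, `CCCCCCN1CCC[C@H]1CNC(=O)c1cc(S(N)(=O)=O)cc2c1O[C@@H](C)C2`, in this assay compound 2 is reported only as a limit, > 100 mg/kg.

Compound 2 therefore stands at the limit of this assay rather than at a number, as the limit of > 100 mg/kg in this assay, at which 1 of the 2 values shown sits, shows. Compound 1 carries an ethyl group on the ring nitrogen and the opposite drawn configuration at the ring carbon, and it gives a measured value where compound 2 gives none; the two compounds differ in two places, so their values alone show only that.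

Compound 3, `CCCCCCN1CCC[C@@H]1CNC(=O)c1cc(S(N)(=O)=O)cc2c1O[C@@H](C)C2`, is the compound not yet measured. It differs from compound 2 in one respect: the two compounds have the same atoms and bonds and differ only in configuration as drawn: 1 of 2 stereo elements differ; a stereocentre at a saturated ring carbon is drawn S in compound 2 and R in compound 3. The change does not add or remove any atom or bond.

Because compound 2 sits at the limit > 100 mg/kg, the step to compound 3 can only go toward smaller doses or stay at the limit. A modest step toward a smaller dose is expected, an at least 1.2-fold lower number from compound 2 to compound 3 (0.09 log units; that floor lies within the scatter), with a real chance that only a limit is again reported. Compound 3 is expected to give about 80 mg/kg, between 30 mg/kg and 250 mg/kg.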

Compound 3, dose for half-maximal effect: 12.2 mg/kg
Compound 3: middle estimate off by 6.6-fold (0.82 log units), on the high side, and the stated range ends above it.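

The inversion alone brings an at least 8.1-fold lower number from compound 2 to compound 3 (0.91 log units; beyond the scatter) in this assay, and this step can be assigned to the stereocentre at the saturated ring carbon, because nothing else changes between the two structures: the fact that compounds 2 and 3 differ only in the configuration as drawn. Compounds 1 and 2 could not show this, as they differ in two places, and the size of the step is only a floor, because compound 2 is reported as a limit and not as a number: the limit of > 100 mg/kg in this assay, at which 1 of the 3 values shown sits. With the ring carbon drawn R in both compounds, butyl in place of hydrogen on a saturated chain carbon, two bonds along the chain from an amine nitrogen in a ring, brings a 5.9-fold lower number from compound 1 to compound 3 (0.77 log units; beyond the scatter), so the hexyl chain in compound 3 goes with an effect at a smaller dose than the ethyl group in compound 1.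

As far as these compounds go, whether the same inversion matters as much with an ethyl group on the ring nitrogen stays open, as does the effect of inverting the other stereo element, which is the same in all three compounds. From the compounds shown here alone, it is also open whether an octyl chain or a benzyl group in place of hexyl would lower the dose further.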